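Swapping a Hydroxyethyl Ether for a Cyclohexyl Ether

The source may report more compounds than this note shows. Statements on the series, on what has been measured and on what is new or still open speak of the compounds shown alone.

Of the compounds shown here, two have so far been measured in a functional assay on SH-SY5Y cells (Homo sapiens) for antagonist activity, read by cAMP accumulation; on this read-out lower numbers stand for lower potency and higher numbers for higher potency (the scale is a negative logarithm). Compound 1 `CCOc1ccc(Cc2ccc(NC3=NCCN3)cc2)cc1` gives 8.2. Compound 2 `OCCOc1ccc(Cc2ccc(NC3=NCCN3)cc2)cc1` gives 8; this is the lower of the two numbers, yet the step of a number 0.20 log units lower from compound 1 to compound 2 (within the scatter) lies within the scatter, so the two compounds cannot be separated on these data. Compound 3 `c1cc(NC2=NCCN2)ccc1Cc1ccc(OC2CCCCC2)cc1` is the next to be tested. It differs from compound 2 in one place: cyclohexyl in place of 2-hydroxyethyl on an oxygen on an aromatic ring. Going by the values given here, the only measured step also altered the group on that same ring oxygen, trading hydrogen for hydroxy on the chain, and it stayed within the scatter. Among the compounds with values here, no measured step removes the chain or puts a ring in its place, so the present change reaches beyond what has been tried. Because a number 0.20 log units lower from compound 1 to compound 2 (within the scatter) was small, the number for compound 3 is expected to stay near that of compound 2, with wide uncertainty. Compound 3 is estimated at 8.1, between 7.3 and 8.9. The step this expectation implies is a number 0.10 log units higher from compound 2 to compound 3 (within the scatter).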

Compound 3, negative logarithm of the antagonist equilibrium constant: 8.6
Compound 3: middle estimate off by 0.50 log units, on the low side; measured number inside the range.
By their numbers in this assay, from the lowest: compounds 2 and 1 (each within the scatter of the next); then compound 3.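

In this assay, the group on the oxygen on the aromatic ring now makes a difference that stands clear of the scatter: cyclohexyl in place of 2-hydroxyethyl gives a number 0.60 log units higher from compound 2 to compound 3 (beyond the scatter), and cyclohexyl in place of ethyl gives a number 0.40 log units higher from compound 1 to compound 3 (beyond the scatter). The earlier step only altered an open chain, whereas these two show that a six-membered carbon ring with no hydrogen-bond donor or acceptor can stand on this oxygen with no loss, and compound 3 ranks highest of the three. Nothing at hand explains why the number rises.

The change brings in a ring and more heavy atoms at once, so the compounds shown cannot tell which of the two matters. Going by these compounds, whether a longer open chain such as hexyl, a smaller ring such as cyclopentyl, or a cyclohexyl carrying an amine would behave the same remains open.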